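Hydroxy to 2-aminophenyl on an amide-type nitrogen

The compounds below may be only part of what the source reports. "The series", "measured", "known", "first", "only" and "open" are said of these compounds alone.

Measured so far:
compound 1 `Cc1cc(F)cc(C)c1Oc1ccc(C(C)(C)O)cc1-c1cn(C)c(=O)c2[nH]c(C(=O)NCc3ccc(C(=O)Nc4ccccc4N)cc3)cc12` gives 240 nM 
compound 2 `Cn1cc(-c2cc(C(C)(C)O)ccc2Oc2ccc(F)cc2F)c2cc(C(=O)NCc3ccc(C(=O)NO)cc3)[nH]c2c1=O` gives 190 nM 

In a functional assay on MV4-11 cells (Homo sapiens) for antiproliferative activity, read by CCK-8 assay, with a stated time of 72 h (a higher number here means a weaker inhibitor, a lower number a stronger inhibitor), compound 2 gives 190 nM and compound 1 gives 240 nM and the two lie within the usual scatter of each other, so neither can be ranked ahead. Compound 3 `Cn1cc(-c2cc(C(C)(C)O)ccc2Oc2ccc(F)cc2F)c2cc(C(=O)NCc3ccc(C(=O)Nc4ccccc4N)cc3)[nH]c2c1=O` has not yet been measured. It keeps the rest of compound 2 and carries 2-aminophenyl in place of hydroxy on an amide-type nitrogen. Among the compounds with values here, no measured pair shows this change on its own. The nearest guide is compound 1, which bears the same 2-aminophenyl on an amide-type nitrogen and gives 240 nM in this assay while differing from compound 3 elsewhere in the molecule. Compound 1 at 240 nM therefore leads to the expectation of no step beyond the scatter in this assay and of no firm direction. The estimated 1.2-fold higher number from compound 2 to compound 3 (0.06 log units; within the scatter) is expected to stay small. In this assay the estimate for compound 3 is 220 nM as an expected value, within an estimated range of 70 nM to 700 nM overall.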

Compound 3, half-maximal inhibitory concentration: 90 nM
Beside the measured number, compound 3's estimate is 2.4-fold (0.39 log units) above it; low and high end bracket the measured number.
By their numbers in this assay, from the lowest: compound 3; then compounds 2 and 1 (each within the scatter of the next).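

In this assay, within the data shown here, putting 2-aminophenyl in place of hydroxy on an amide-type nitrogen while the rest of the molecule stays the same gives a 2.1-fold lower number from compound 2 to compound 3 (0.32 log units; beyond the scatter), the first direct reading of this change, modest but beyond the scatter. With 2-aminophenyl held on that nitrogen, 2,4-difluorophenyl in place of 4-fluoro-2,6-dimethylphenyl on an oxygen on an aromatic ring gives a 2.7-fold lower number from compound 1 to compound 3 (0.43 log units; beyond the scatter), so the group on that oxygen also shifts the number by a modest step beyond the scatter. Compound 1 and compound 2 differ in both places. Neither effect could be read before compound 3.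

From the compounds shown here alone, each step rests on a single pair in a single cell assay, so it remains open whether the change from hydroxy to 2-aminophenyl gives a similar step with 4-fluoro-2,6-dimethylphenyl on the oxygen, and how an unsubstituted phenyl or a 2-hydroxyphenyl on the amide-type nitrogen would compare. No evidence is available to explain either step.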